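Replacing a pyridinyl ring with an amide on a shared core

A few compounds are considered here, and "the series" means these few. Any claim that something is new, unique, unknown or untested is made for them only; others in the source may bear on it.

Compound 2 `CCCCN(c1nc2c(-c3ccccn3)cccc2o1)[C@H](C)c1ccc(-c2ccccc2-c2nnn[nH]2)cc1` gives 5.9 h in an ADME assay on the whole organism (Macaca fascicularis) for metabolic stability, read by LC-MS, using cassette dosing, at a dose of 1 mg/kg by the oral route; on this read-out higher numbers stand for a longer-lived compound and lower numbers for a shorter-lived compound; compound 1 `CCCCN(c1nc2c(-c3nccn3C)cccc2o1)[C@H](C)c1ccc(-c2ccccc2-c2nnn[nH]2)cc1` gives 3.9 h, and the step of a 1.5-fold higher number from compound 1 to compound 2 (0.18 log units; within the scatter) keeps the two within the usual scatter. Compound 3 `CCCCN(c1nc2c(C(=O)N(C)C)cccc2o1)[C@H](C)c1ccc(-c2ccccc2-c2nnn[nH]2)cc1` carries dimethylcarbamoyl in place of pyridin-2-yl on an aromatic carbon. Among the measured compounds shown here, the only measured step swaps one aromatic ring for another and so does not bear directly on trading a ring for an amide; it only shows that a change at this position left the half-life roughly unchanged. Compound 3 is therefore expected at 4.5 h, between 2 h and 10 h, a step of a 1.3-fold lower number from compound 2 to compound 3 (0.12 log units; within the scatter) that is expected to stay within the scatter.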

Compound 3, half-life: 3.2 h
Compound 3: the middle estimate sits 1.4-fold (0.15 log units) above what was measured; the measured number falls inside the stated range.
By their numbers in this assay, from the lowest: compounds 3, 1 and 2 (each within the scatter of the next).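

In this assay, dimethylcarbamoyl in place of pyridin-2-yl gives a 1.8-fold lower number from compound 2 to compound 3 (0.27 log units; within the scatter), and dimethylcarbamoyl in place of 1-methyl-1H-imidazol-2-yl gives a 1.2-fold lower number from compound 1 to compound 3 (0.09 log units; within the scatter). So at this position on the shared core, a group with no ring keeps the half-life within the scatter of both ring-bearing compounds, which the swap of one aromatic ring for another could not show. Nothing measured here offers an explanation for this result. Still open, on these data alone, is whether a carboxylic acid or a primary amine at this position would do the same, and whether longer chains on the amide nitrogen would.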